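A Benzylamine Swap on the Least Soluble Analogue

The source may report more compounds than this note shows. Statements on the series, on what has been measured and on what is new or still open speak of the compounds shown alone.

Of the compounds shown here, three have been measured in a physicochemical assay for solubility, with a stated time of 18 h, at pH 7.4; on this read-out higher numbers stand for higher solubility and lower numbers for lower solubility. Compound 1 `COc1cccc(CNCCCNc2ccnc3cc(-c4ccc(F)cc4)ccc23)c1O` gives 32000 nM, compound 2 `COc1ccccc1Oc1ccc2c(NCCCNCc3ccco3)ccnc2c1` gives 14500 nM, and compound 3 `Fc1ccc(Cc2ccc3c(NCCCNCc4ccco4)ccnc3c2)c(Cl)c1` gives 4200 nM. Compound 3 stands lowest of the three; its nearest neighbour is compound 2, and the gap to compound 1 is wider still. For the measured compounds named here, the only single-point step in this set is a 3.5-fold lower number from compound 2 to compound 3 (0.54 log units; beyond the scatter), which concerns the group on an aromatic carbon of the shared core rather than the amine end of the chain.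

Compound 4 `COc1cccc(CNCCCNc2ccnc3cc(Cc4ccc(F)cc4Cl)ccc23)c1O` keeps the core of compound 3 and alters the chain end: 2-hydroxy-3-methoxyphenyl in place of furan-2-yl on a saturated chain carbon bound to an amine nitrogen. Going by the values given here, no measured pair isolates this exchange. Compound 1 carries the same 2-hydroxy-3-methoxybenzyl group and shows the highest number of the three, while compound 2, with the (furan-2-yl)methyl group, sits between; yet compound 1 and compound 2 differ in two places, so their values show only the two readings and not a step. On that basis compound 4 is expected to move by a 1.4-fold higher number from compound 3 to compound 4 (0.15 log units; within the scatter), a modest rise with wide uncertainty. Compound 4 is thus estimated at 6000 nM in this assay, with an expected range from 2500 nM to 16000 nM.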

Compound 4, solubility: 4200 nM
Compound 4: middle estimate off by 1.4-fold (0.15 log units), on the high side; the measured number falls inside the stated range.
By their numbers in this assay, from the lowest: compounds 3 and 4 (each within the scatter of the next); then compound 2; then compound 1.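

In this assay, for the compounds shown here, 2-hydroxy-3-methoxyphenyl in place of furan-2-yl on a saturated chain carbon bound to an amine nitrogen gives no change at the digits printed from compound 3 to compound 4 (within the scatter), the first reading of this exchange in a single-point pair, and with 2-chloro-4-fluorobenzyl on the shared core the two groups are not separated. The new compound also gives a second step on the aromatic carbon, with 2-chloro-4-fluorobenzyl in place of 4-fluorophenyl, where the 2-hydroxy-3-methoxybenzyl end stays fixed: a 7.6-fold lower number from compound 1 to compound 4 (0.88 log units; beyond the scatter), which joins a 3.5-fold lower number from compound 2 to compound 3 (0.54 log units; beyond the scatter) as a second lower number on entry of the same group, from a different starting group and with a different chain end. No supporting measurement is available to account for either result.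

The compounds shown leave open whether the exchange of furan-2-yl for 2-hydroxy-3-methoxyphenyl would read the same with 2-methoxyphenoxy or 4-fluorophenyl on the aromatic carbon, since this one pair speaks only for 2-chloro-4-fluorobenzyl. Also open, going by these compounds, is how the read-out would respond to a carboxylic acid or a morpholine on that saturated chain carbon in place of either aromatic ring.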